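Two bis-hydroxyphenyl pyridines inactive; a third moves the hydroxyl

This account rests on a few compounds, and the source may have more. Where it says the series, first, only, none or still open, it means among the compounds named here.

Measured so far:
- compound 1, `Oc1ccc(-c2cc(-c3cccc(F)c3)cc(-c3ccccc3O)n2)cc1`: in a functional assay on T47D cells (Homo sapiens) for inhibition (a higher number here means a weaker inhibitor, a lower number a stronger inhibitor), compound 1 gives only the assay limit > 50000 nM.
- compound 2, `Oc1ccccc1-c1cc(-c2cccc(OC(F)(F)F)c2)cc(-c2ccccc2O)n1`: in this assay compound 2 gives only the assay limit > 50000 nM.

Compound 2 therefore stands at no number at all but at the limit of > 50000 nM in this assay, at which 2 of the 2 values shown sit, and so does compound 1; neither value can be placed above or below the other. The two share a common core and differ only in the group carried on the distal phenyl ring, a fluorine in compound 1 and a trifluoromethoxy in compound 2, and in where the hydroxyl sits on one of the hydroxyphenyl arms.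

Compound 3, `Oc1ccc(-c2cc(-c3cccc(OC(F)(F)F)c3)cc(-c3ccccc3O)n2)cc1`, is made from compound 2 by 4-hydroxyphenyl in place of 2-hydroxyphenyl on an aromatic carbon. Compound 1 already carries the 4-hydroxyphenyl arm that compound 3 gains and sits at the limit; compound 2 carries the trifluoromethoxyphenyl that compound 3 keeps and sits at the limit too. Among the compounds with values here, no measured step is available for this change, so the expectation in this assay is no movement beyond the scatter, the step from compound 2 to compound 3 being estimated as a step that the limit leaves unreadable from compound 2 to compound 3. Compound 3 is therefore expected to give 70000 nM, within 20000 nM to 250000 nM, most probably again reported only as a limit.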

Compound 3, half-maximal inhibitory concentration: > 50000 nM
Compound 3 was reported as a limit; the forecaster's own chance of this, stated with the estimate: 85%; the middle value does not contradict the limit.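

Within the data shown here, compound 3, like compound 1 and compound 2, is reported in this assay only as a limit, so neither the step from compound 2 to compound 3 nor the one from compound 1 to compound 3 can be read: the limit of > 50000 nM in this assay, at which 3 of the 3 values shown sit.

The compounds shown leave open how the 4-hydroxyphenyl and 2-hydroxyphenyl arms, or the trifluoromethoxy and fluoro groups, compare in this assay.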